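Carboxylic acid replaces methyl ester on a linked aryl ether

This account rests on a few compounds, and the source may have more. Where it says the series, first, only, none or still open, it means among the compounds named here.

Compound 1 `Cc1c(OCCCCOc2ccccc2C(=O)O)ccc(C(=O)CC2CCCC2)c1O` — 335 nM
Compound 2 `Cc1cc(OCCCCOc2ccc(C(=O)CC3CCCC3)c(O)c2C)ccc1C(=O)O` — 564 nM
Compound 3 `COC(=O)c1ccc(OCCCCOc2ccc(C(=O)CC3CCCC3)c(O)c2C)cc1` — "not determined" (no result reported)

Three compounds sharing one core were examined in an assay on HEK293 cells for positive allosteric modulation of metabotropic glutamate receptor 2 (Rattus norvegicus), read by thallium flux, with a stated time of 2.5 min; on this read-out lower numbers stand for an effect already at smaller amounts and higher numbers for an effect only at larger amounts of compound. Compound 1 gives 335 nM and compound 2 gives 564 nM; the step of a 1.7-fold higher number from compound 1 to compound 2 (0.23 log units; within the scatter) does not leave the scatter. For compound 3 the result is "not determined" (no result reported), so it stands without a place on this scale. Compound 4 `Cc1cc(C(=O)O)ccc1OCCCCOc1ccc(C(=O)CC2CCCC2)c(O)c1C` differs from compound 3 by 4-carboxy-2-methylphenyl in place of 4-(methoxycarbonyl)phenyl on an oxygen on a saturated carbon. Within the data shown here, neither measured step touches an ester, so none bears directly on this change; the only guide is that both acid-bearing compounds, compound 1 and compound 2, sit within the scatter of each other. Compound 4 is therefore expected to fall near them, estimated at 500 nM within 180 nM to 1400 nM.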

Compound 4, half-maximal effective concentration: 608 nM
The estimate for compound 4 lay 1.2-fold (0.08 log units) below the measured number; the range from low to high includes it.
By their numbers in this assay, from the lowest: compounds 1, 2 and 4 (each within the scatter of the next).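

In this assay, 4-carboxy-2-methylphenyl in place of 4-carboxy-3-methylphenyl gives a 1.1-fold higher number from compound 2 to compound 4 (0.03 log units; within the scatter), and in place of 2-carboxyphenyl it gives a 1.8-fold higher number from compound 1 to compound 4 (0.26 log units; within the scatter). On this oxygen on a saturated carbon, all three carboxyphenyl groups shown therefore read alike, whichever of these arrangements is present. No evidence is available to explain this. With no number for compound 3, the change from the methyl ester to the acid cannot be read. From the compounds shown here alone, whether a primary amide or a tetrazole could stand in for the carboxylic acid remains open.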